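The compounds below may be only part of what the source reports. "The series", "measured", "known", "first", "only" and "open" are said of these compounds alone.

Compound 1 `CCCCCN(CCCCC)c1nc2c(ncn2-c2ccccc2)c(=O)n1-c1ccc(Cl)cc1`, compound 2 `O=c1c2ncn(-c3ccccc3)c2nc(N2CCCCC2)n1-c1ccc(Cl)cc1` and compound 3 `CNc1nc2c(ncn2-c2ccccc2)c(=O)n1-c1ccc(Cl)cc1` share one core and differ only in the amino group on an aromatic carbon. In a functional assay on KB cells (Homo sapiens) for cytotoxicity, read by MTT assay, with a stated time of 72 h (a lower number here means a stronger inhibitor, a higher number a weaker inhibitor), compound 1 gives 10600 nM, and compound 2 gives 72800 nM. Compound 3 in this assay reaches only a limit, > 100000 nM. This is the limit of > 100000 nM in this assay, at which 1 of the 3 values shown sits. Against compound 1 the gap is clear, an at least 9.4-fold higher number from compound 1 to compound 3 (0.97 log units; beyond the scatter), whereas an at least 1.3-fold higher number from compound 2 to compound 3 (0.13 log units; that floor lies within the scatter). Compound 4 `CCCCNc1nc2c(ncn2-c2ccccc2)c(=O)n1-c1ccc(Cl)cc1` differs from compound 3 by propyl in place of hydrogen on a saturated chain carbon bound to a nitrogen on an aromatic ring. Among the measured compounds the number falls as the amino substituent grows, and none of the three goes against this. The change is therefore expected to lower the number, by an at least 1.6-fold lower number from compound 3 to compound 4 (0.22 log units; that floor lies within the scatter). Compound 4 is estimated at 60000 nM, between 15000 nM and 200000 nM.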

Compound 4, half-maximal inhibitory concentration: 37700 nM
The estimate for compound 4 lay 1.6-fold (0.20 log units) above the measured number, and the stated range covers the measured number.
By their numbers in this assay, from the lowest: compound 1; then compounds 4 and 2 (each within the scatter of the next). At a limit, above all of these: compound 3.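

In this assay, the butylamino group of compound 4 brings the number down from the limit held by compound 3, with an at least 2.6-fold lower number from compound 3 to compound 4 (0.42 log units; beyond the scatter), though this step is only a floor: the limit of > 100000 nM in this assay, at which 1 of the 4 values shown sits.

Butylamino cannot be told apart from piperidin-1-yl, with a 1.9-fold lower number from compound 2 to compound 4 (0.29 log units; within the scatter), but it does not reach dipentylamino, with a 3.6-fold higher number from compound 1 to compound 4 (0.55 log units; beyond the scatter). The compounds shown leave open whether chain length alone sets the number, or whether a second chain on the nitrogen also counts, as dibutylamino would show against butylamino. Going by these compounds, how a hydroxybutylamino group would compare with butylamino also stays open.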